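The source may report more compounds than this note shows. Statements on the series, on what has been measured and on what is new or still open speak of the compounds shown alone.

Of the compounds shown here, two have so far been measured in a functional assay on HEK293 cells for activation of melanin-concentrating hormone receptor 1 (Homo sapiens), read by inositol phosphate accumulation; a lower number here means that less compound is needed, a higher number that more compound is needed for the effect. Compound 1 `CCCc1ccc(/C=C/C(=O)Nc2ccc3nc(CCC)cc(N)c3c2)cc1` gives 3600 nM in this assay, and compound 2 `CCCc1cc(N)c2cc(NC(=O)/C=C/c3ccc(C(C)C)cc3)ccc2n1` gives 520 nM. The two differ in a single group on the phenyl ring, and the step between them is a 6.9-fold lower number from compound 1 to compound 2 (0.84 log units; beyond the scatter). For the measured compounds named here, compound 2 thus stands at the lower of the two numbers, with compound 1 as its only neighbour and beyond the scatter from it.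

Compound 3 `CCCc1cc(N)c2cc(NC(=O)/C=C/c3ccccc3Cl)ccc2n1` has not yet been measured in this assay. It keeps the shared core and the double-bonded chain and changes the group on the double-bonded chain carbon: 2-chlorophenyl in place of 4-isopropylphenyl on a double-bonded chain carbon bound to a double-bonded chain carbon. Going by the values given here, no measured step covers this exchange. Among the compounds with values here, the one step at hand, from compound 1 to compound 2, shows that altering this ring can shift the number beyond the scatter, but it swaps one group for another on the ring rather than exchanging the whole ring with its chlorine, so it suggests a size without a direction. The estimate for compound 3 is therefore set wide, at 2000 nM with a range from 300 nM to 15000 nM. This corresponds to an expected step of a 3.8-fold higher number from compound 2 to compound 3 (0.59 log units; beyond the scatter).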

Compound 3, half-maximal effective concentration: 500 nM
Estimate against measurement, compound 3: 4.0-fold (0.60 log units) above; the range from low to high includes it.
By their numbers in this assay, from the lowest: compounds 3 and 2 (each within the scatter of the next); then compound 1.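

Changing the whole ring group in this assay gives a 1.0-fold lower number from compound 2 to compound 3 (0.02 log units; within the scatter) and so leaves the number within the scatter: at this place, on a double-bonded chain carbon bound to a double-bonded chain carbon, 2-chlorophenyl and 4-isopropylphenyl cannot be told apart, even though the first brings a chlorine and 7 heavy atoms where the second has 9 carbons. The other new step is a 7.2-fold lower number from compound 1 to compound 3 (0.86 log units; beyond the scatter) and lies beyond the scatter, so compound 1 with its 4-propylphenyl group now stands apart from two different groups and not just from one. A carbon-only branched group on the ring is therefore not needed to reach the level of compound 2, at least among these three compounds.

Still open, as far as these compounds go, is what the chlorine itself contributes, and whether a plain phenyl ring, a 4-chlorophenyl group or a methoxy-bearing phenyl ring would stay at this level or move away from it. No measurement at hand speaks to why these three groups give the numbers they do.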